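The source may hold more compounds than are shown below. What is called first, only, known or untested is meant among the compounds shown, and "the series" means these compounds.

The three measured compounds share a core and differ in one group. In an ADME assay on microsomes from liver (Homo sapiens) for metabolic stability, read by HPLC, using NADPH, with stated times of 5 min and 60 min, tested at 10 uM (on this read-out higher numbers stand for fast clearance and lower numbers for slow clearance), compound 1 `CCS(=O)(=O)Nc1ccc(Oc2ccccc2)c(-c2cn(C)c(=O)c3[nH]ccc23)c1` gives < 45 mL/min/kg, which is a limit and not a number. Compound 3 `Cn1cc(-c2cc(S(N)(=O)=O)ccc2Oc2ccccc2)c2cc[nH]c2c1=O` gives < 43.4 mL/min/kg, which is also only a limit. Among the compounds with values here, compound 2 `Cn1cc(-c2cc(C(N)=O)ccc2Oc2ccccc2)c2cc[nH]c2c1=O` gives 48.3 mL/min/kg, the only true number of the three. The starting point, compound 1, is therefore known only as a limit.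

Compound 4 `CCS(=O)(=O)Nc1ccc(OC2CCC(N(C)C)CC2)c(-c2cn(C)c(=O)c3[nH]ccc23)c1` keeps the (ethylsulfonyl)amino group of compound 1 and changes the other side of the molecule: 4-(dimethylamino)cyclohexyl in place of phenyl on an oxygen on an aromatic ring. In words, this puts 4-(dimethylamino)cyclohexyl in place of phenyl on an oxygen on an aromatic ring.

Within the data shown here, none of the measured steps touches that phenyl. They replace or alter the other group instead. The first is an at least 1.0-fold higher number from compound 1 to compound 2 (0.03 log units; that floor lies within the scatter), the second is an at least 1.1-fold lower number from compound 2 to compound 3 (0.04 log units; that floor lies within the scatter), and the third is a step that the two limits leave unreadable from compound 1 to compound 3. Among the measured compounds shown here, these steps give no direct size for the new change, so the one true number, from compound 2 at 48.3 mL/min/kg, serves as a rough anchor. The expected result is an at least 1.2-fold higher number from compound 1 to compound 4 (0.08 log units; that floor lies within the scatter), a modest rise held with wide uncertainty. For compound 4 the estimated clearance is 55 mL/min/kg, with an expected range from 38 mL/min/kg to 100 mL/min/kg.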

Compound 4, clearance: < 26.7 mL/min/kg
Compound 4 was reported as a limit; the forecaster's own chance of this, stated with the estimate: 30%; middle value at least 2.0-fold (0.31 log units) away from the limit.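

In this assay compound 4 gives < 26.7 mL/min/kg, which is a limit and not a number. Compound 1 is also known only as a limit, and the step between compound 1 and compound 4 cannot be read. The compounds shown leave open how large a change in clearance comes with 4-(dimethylamino)cyclohexyl in place of phenyl.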